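Compound 3 and the aromatic nitrogen swap

The source may hold more compounds than are shown below. What is called first, only, known or untested is meant among the compounds shown, and "the series" means these compounds.

In an ADME assay for permeability (on this read-out lower numbers stand for lower permeability and higher numbers for higher permeability), compound 3 (`CNC(=O)c1cc(C(=O)N[C@H]2[C@@H]3C[C@H](O)C[C@@H]32)n([C@@H](C)c2cccc(Cl)c2)n1`) gives 333 nm/s as its reading. Compound 1 (`CNC(=O)c1cc(C(=O)N[C@H]2CC[C@H](O)CC2)n([C@@H](C)c2cccc(Cl)c2)n1`) at 235 nm/s stands level with it, with a 1.4-fold higher number from compound 1 to compound 3 (0.15 log units; within the scatter) as the step between them. Compound 2 (`CC(=O)Nc1c(F)cc(C(=O)N[C@H]2CC[C@H](O)CC2)cc1O[C@@H](C)c1ccccc1`) at 17 nm/s lies far lower than both. Compound 4 (`CC[C@@H](c1ccccc1)n1nc(C(=O)NC)cc1C(=O)N[C@H]1[C@@H]2C[C@H](O)C[C@@H]21`) differs from compound 3 on an aromatic nitrogen, where 1-phenylpropyl stands in place of 1-(3-chlorophenyl)ethyl (1-phenylpropyl in place of 1-(3-chlorophenyl)ethyl on an aromatic nitrogen). Going by the values given here, the one measured step changes a different group, on an amide-type nitrogen, so no measured step bears directly on this swap. In this assay no change beyond the scatter is therefore expected, with an estimated 1.1-fold lower number from compound 3 to compound 4 (0.05 log units; within the scatter) as the step. For compound 4 the estimate is 300 nm/s with 130 nm/s to 650 nm/s as its expected range.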

Compound 4, apparent permeability: 230 nm/s
Beside the measured number, compound 4's estimate is 1.3-fold (0.12 log units) above it; the range from low to high includes it.
By their numbers in this assay, from the lowest: compound 2; then compounds 4, 1 and 3 (each within the scatter of the next).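

Going by these compounds alone, on the aromatic nitrogen of the shared core, this assay gives a 1.4-fold lower number from compound 3 to compound 4 (0.16 log units; within the scatter) with 1-phenylpropyl in place of 1-(3-chlorophenyl)ethyl, the first measured step at this position. The two groups therefore read alike here, although this single swap cannot separate the loss of the chlorine from the change in the chain. Nothing available explains this result.

As far as these compounds go, it remains open whether an amine or a carboxylic acid on the phenyl ring would also stay within the scatter. Also open, from the compounds shown here alone, is whether the same swap would read alike on the core of compound 1.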